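Hydrazone series: chloro for hydroxy, cytotoxicity estimate

This account rests on a few compounds, and the source may have more. Where it says the series, first, only, none or still open, it means among the compounds named here.

Three hydrazones sharing one core have been run in an ADME assay on HEL cells (Homo sapiens) for cytotoxicity; on this read-out lower numbers stand for higher toxicity in this test and higher numbers for lower toxicity in this test. Compound 1 `O=C(COc1cccc2ccccc12)N/N=C/c1c(O)ccc2ccccc12` gives 1.94 ug/mL. Compound 2 `O=C(COc1cccc2ccccc12)N/N=C/c1ccc(O)cc1` gives 60.6 ug/mL, and compound 3 `O=C(COc1cccc2ccccc12)N/N=C/c1cccc([N+](=O)[O-])c1` gives 61.2 ug/mL. On these three numbers compound 2 stands second highest; its nearest neighbour is compound 3, whose number lies within the scatter of compound 2, so no order between compound 2 and compound 3 can be read. Its furthest neighbour is compound 1, whose number is lower by a margin beyond the scatter, so compound 1 is the more toxic of that pair in this assay.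

The next compound, compound 4 `O=C(COc1cccc2ccccc12)N/N=C/c1ccc(Cl)cc1`, is not yet measured. Relative to compound 2 the change is chloro in place of hydroxy on an aromatic carbon; cut one bond further out, the same difference reads 4-hydroxyphenyl to 4-chlorophenyl. Among the measured compounds shown here, no measured pair in the set carries this change, so nothing here tells what size of step to expect; the two phenyl compounds 2 and 3 sit together, while compound 1 differs in more than this one place.

For compound 4 in this assay a step of a 1.5-fold lower number from compound 2 to compound 4 (0.18 log units; within the scatter) is expected, of a size no larger than the scatter or only slightly beyond it, if anything toward a lower number. Compound 4 is therefore estimated at 40 ug/mL, within 12 ug/mL to 110 ug/mL.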

Compound 4, half-maximal cytotoxic concentration: 100 ug/mL
Compound 4: middle estimate off by 2.5-fold (0.40 log units), on the low side, and the stated range covers the measured number.
By their numbers in this assay, from the lowest: compound 1; then compounds 2, 3 and 4 (each within the scatter of the next).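

In this assay, among the compounds shown here, the exchange of hydroxy for chloro gives a 1.7-fold higher number from compound 2 to compound 4 (0.22 log units; within the scatter) and so provides the first step between compounds differing in one place. At this aromatic carbon, para to a large group, the read-out does not separate the two groups, even though the exchange takes away the hydrogen-bond donor and acceptor counted for hydroxy. No measurement at hand addresses why the two groups read alike, so no cause is assigned to this result.

This single pair speaks only for this position on this core, and an amine, a methoxy group, a carboxylic acid or a longer alkyl chain at the same carbon could each read differently, so further one-place pairs are needed to show whether the read-out responds to any change here. Also unanswered is whether chloro in place of hydroxy would read the same on another carbon of the ring or on the core of compound 1.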